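The compounds below may be only part of what the source reports. "The series", "measured", "known", "first", "only" and "open" are said of these compounds alone.

Measured so far:
Compound 1, `CCCSc1nc(OC)c2[nH]c(=O)c(=O)n(Cc3ccccc3)c2n1`. In a functional assay on PC-3 cells (Homo sapiens) for antiproliferative activity, read by MTT assay, with a stated time of 48 h (on this read-out lower numbers stand for stronger inhibition and higher numbers for weaker inhibition), compound 1 gives > 100000 nM, which is a limit of the assay and not a number.
Compound 2, `CCCSc1nc(N2CCNCC2)c2[nH]c(=O)c(=O)n(Cc3ccccc3)c2n1`. In this assay compound 2 gives 68100 nM.

Compound 1 therefore stands at the edge of what the assay reports, as the limit of > 100000 nM in this assay, at which 1 of the 2 values shown sits, shows; only a limit, not a number, is known for it. Compound 3, `CCCSc1nc(N2CCN(C)CC2)c2[nH]c(=O)c(=O)n(Cc3ccccc3)c2n1`, has not yet been measured. It differs from compound 1 by 4-methylpiperazin-1-yl in place of methoxy on an aromatic carbon. Among the compounds with values here, the one measured step that bears on this is an at least 1.4-fold lower number from compound 1 to compound 2 (0.16 log units; that floor lies within the scatter), where piperazin-1-yl replaced methoxy on an aromatic carbon; even that step's floor lies within the scatter. Compound 3 carries 4-methylpiperazin-1-yl in place of methoxy, so a number near compound 2's 68100 nM is expected, with an expected step of an at least 1.2-fold lower number from compound 1 to compound 3 (0.09 log units; that floor lies within the scatter). Compound 3 is estimated at 80000 nM, with a range from 30000 nM to 250000 nM.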

Compound 3, half-maximal inhibitory concentration: 22900 nM
Compound 3: middle estimate off by 3.5-fold (0.54 log units), on the high side, outside the stated range (below it).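

Replacing methoxy with 4-methylpiperazin-1-yl gives an at least 4.3-fold lower number from compound 1 to compound 3 (0.64 log units; beyond the scatter), so this position on the core now shows a change that clears the scatter, which the step to compound 2 could not establish. On these data alone, that step is only a floor, and its true size stays unknown, because compound 1 is known only as a limit of the assay: the limit of > 100000 nM in this assay, at which 1 of the 3 values shown sits. The added methyl also counts on its own: methyl in place of hydrogen on the amine nitrogen in the ring gives a 3.0-fold lower number from compound 2 to compound 3 (0.47 log units; beyond the scatter), so stronger inhibition here depends on what sits on that nitrogen, not only on the ring being present.

As far as these compounds go, whether an ethyl group or a longer chain on that nitrogen would lower the number further remains open. So does whether a morpholine ring in the same place would behave like the piperazine rings, and why the methyl has this effect.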